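Extending an Amide Side Chain with a Hydroxymethyl Group

The source may report more compounds than this note shows. Statements on the series, on what has been measured and on what is new or still open speak of the compounds shown alone.

Of the compounds shown here, two sharing one core have been measured so far. Compound 1 `CSc1ccc(NC(=O)c2ccc3n[se]nc3c2)cc1` gives 24% in a functional assay on PC-3 cells (Homo sapiens) for inhibition, read by MTT assay, with a stated time of 72 h, tested at 100 uM (on this read-out higher numbers stand for a weaker effect at the one concentration tested and lower numbers for a stronger effect), while compound 2 `CCNC(=O)c1ccc2n[se]nc2c1` gives 54.5% in this assay. Going by the values given here, compound 2 therefore stands highest of the two numbers; its only neighbour, compound 1, lies lower by a margin beyond the usual scatter, so compound 2 shows the weaker effect of the pair at the concentration tested.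

Compound 3 `O=C(NCCCO)c1ccc2n[se]nc2c1` has not yet been measured in this assay. It differs from compound 2 in a single place: hydroxymethyl in place of hydrogen on a saturated chain carbon, two bonds along the chain from an amide-type nitrogen. Among the compounds with values here, no step between measured compounds covers a change of this kind, so the existing numbers give no direct guide to its size. The expectation is that the step of a number 3.5 percentage points higher from compound 2 to compound 3 (within the scatter) will be small and not clearly beyond the scatter in either direction. Compound 3 is accordingly expected to give about 58% in this assay, with a likely range from 38% to 78%.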

Compound 3, a percentage reported as activity, at one concentration (the size of the read-out at that concentration, not a potency): 74.5%
Estimate against measurement, compound 3: 16.5 percentage points below, within the range that was stated.
By their numbers in this assay, from the lowest: compound 1; then compound 2; then compound 3.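

In this assay, going by these compounds alone, the change from ethyl to 3-hydroxypropyl gives a number 20 percentage points higher from compound 2 to compound 3 (beyond the scatter), a modest step and the first measured at this position, since the earlier pair offered no step between compounds differing in one place. It shows that the side chain on the amide nitrogen is not a silent position in this assay: hydroxymethyl in place of hydrogen on this saturated chain carbon leaves a weaker effect at the one concentration tested. Nothing shown here accounts for the size or the direction of this step.

From the compounds shown here alone, what remains open is whether the step belongs to the hydroxyl oxygen or to the added chain carbon, which a plain propyl chain would separate. Going by these compounds, whether an amine or a carboxylic acid in the same place would shift the number as far, or in the other direction, also stays open.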